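Extending compound 1 with a trifluoromethylphenyl arm

The compounds below may be only part of what the source reports. "The series", "measured", "known", "first", "only" and "open" are said of these compounds alone.

Compound 1 `CC(C)c1cccc(NC(=O)CCc2cccc3c2B(O)OC3)c1` is the reference point of this small set. In a functional assay on HCT-116 cells (Homo sapiens) for antiproliferative activity, read by MTT assay, with a stated time of 72 h (on this read-out higher numbers stand for weaker inhibition and lower numbers for stronger inhibition), compound 1 gives 1600 nM, the lowest of the two numbers recorded. Among the compounds with values here, its only measured neighbour, compound 2 `Cc1cc(C)c(NC(=O)CCc2cccc3c2B(O)OC3)c(C)c1`, gives 64000 nM in this assay, a much higher number; the gap between the two lies well beyond the scatter of repeated measurements, although no direct single-point step links them.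

The next compound, compound 3 `O=C(CCc1cccc2c1B(O)OC2)Nc1cccc(-c2cccc(C(F)(F)F)c2)c1`, keeps the shared core and the amide linker of compound 1 and alters only the substituent on the aniline ring: 3-(trifluoromethyl)phenyl in place of isopropyl on an aromatic carbon. The group that enters is a six-membered aromatic ring of carbon only bearing a trifluoromethyl group, placed on the aromatic carbon that held the isopropyl, meta to a large group.

Within the data shown here, no measured pair shows the consequence of such an exchange, so the expectation rests on compound 1 alone. Compound 3 is expected to give 1000 nM in this assay, within 200 nM to 8000 nM, a step of a 1.6-fold lower number from compound 1 to compound 3 (0.20 log units; within the scatter) that would stay close to the scatter.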

Compound 3, half-maximal inhibitory concentration: 580 nM
For compound 3 the middle estimate is 1.7-fold (0.24 log units) above the measured one; the range from low to high includes it.
By their numbers in this assay, from the lowest: compound 3; then compound 1; then compound 2.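

Within the data shown here, the exchange of isopropyl for 3-(trifluoromethyl)phenyl gives a 2.8-fold lower number from compound 1 to compound 3 (0.44 log units; beyond the scatter) in this assay, and this is the first single-place step in the set. It shows that this aromatic carbon, meta to a large group, accepts a group of 10 heavy atoms with a six-membered aromatic ring of carbon only, where the isopropyl had 3 heavy atoms and no ring, and that the number does not rise but falls by a modest step beyond the scatter. Nothing measured alongside this result accounts for the change, so the step stands as an observation without an explanation.

The compounds shown do not separate the contribution of the added ring from that of its trifluoromethyl group, a question that a plain phenyl on the same aromatic carbon would address. They also leave open whether the ring would keep this level of inhibition with an amine or a carboxylic acid in place of the trifluoromethyl group, and whether a longer alkyl chain in place of the isopropyl would move the number in the same direction.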